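This account rests on a few compounds, and the source may have more. Where it says the series, first, only, none or still open, it means among the compounds named here.

Measured so far in a functional assay on MCF7 cells (Homo sapiens) for cytotoxicity, read by CellTiter-Glo, with a stated time of 5 days; on this read-out higher numbers stand for weaker inhibition and lower numbers for stronger inhibition: compound 1 `CCC/C(=C(/c1ccc(/C=C/C(=O)O)cc1)c1ccc2[nH]ncc2c1)c1ccccc1` gives 11 nM; compound 2 `CC/C(=C(/c1ccc(/C=C/C(=O)O)cc1)c1cc2cn[nH]c2cn1)c1ccccc1` gives 442 nM; compound 3 `CC/C(=C(/c1ccc(/C=C/C(=O)O)cc1)c1cc2cn[nH]c2cc1C)c1ccccc1` gives 468 nM.

Compound 3 gives the highest of the three numbers in this assay; its nearest neighbour is compound 2, within the scatter, while compound 1 gives a far lower number, beyond the scatter. For the measured compounds named here, the one single-place step among the measured compounds, a 1.1-fold higher number from compound 2 to compound 3 (0.02 log units; within the scatter), concerns a different exchange than the one at hand.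

Compound 4 `CC/C(=C(/c1ccc(/C=C/C(=O)O)cc1)c1cc2cn[nH]c2cc1F)c1ccccc1` differs from compound 3 by fluoro in place of methyl on an aromatic carbon. Going by the values given here, no measured step bears on this exchange, so the step of a 1.1-fold lower number from compound 3 to compound 4 (0.05 log units; within the scatter) is expected to stay within the scatter, with no direction preferred. Compound 4 is therefore expected to give about 420 nM in this assay, within the range 150 nM to 1200 nM.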

Compound 4, half-maximal inhibitory concentration: 47 nM
Compound 4: middle estimate off by 8.9-fold (0.95 log units), on the high side; measured number below the stated range.
By their numbers in this assay, from the lowest: compound 1; then compound 4; then compounds 2 and 3 (each within the scatter of the next).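

In this assay, the aromatic carbon ortho to a large group proves sensitive to what it carries: fluoro in place of methyl brings a 10-fold lower number from compound 3 to compound 4 (1.00 log units; beyond the scatter) in a swap of one heavy atom for one. The 6-fluoro-1H-indazol-5-yl group also separates from the group of compound 2, with a 9.4-fold lower number from compound 2 to compound 4 (0.97 log units; beyond the scatter) where the methyl analogue had shown only a 1.1-fold higher number from compound 2 to compound 3 (0.02 log units; within the scatter) at the same place. No measurement given here speaks to why fluoro and methyl differ on this carbon. From the compounds shown here alone, what chloro, methoxy or a nitrile on this aromatic carbon would give remains open. So does whether fluoro would have a like effect on the core of compound 1.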